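Isopropylamino against propylamino on two halogenated cores

This account rests on a few compounds, and the source may have more. Where it says the series, first, only, none or still open, it means among the compounds named here.

Compound 1 `CCCNC1=NS(=O)(=O)c2cc(Cl)c(Cl)cc2N1` is the propylamino member of a dichloro core; in a functional assay (aorta) with Rattus norvegicus as the target, with a stated time of 90 min, at 37 degrees C (on this read-out lower numbers stand for an effect already at smaller amounts and higher numbers for an effect only at larger amounts of compound), compound 1 gives 4700 nM. Compound 2 `CC(C)NC1=NS(=O)(=O)c2cc(Cl)c(Cl)cc2N1` carries the change isopropyl in place of propyl on an amine nitrogen and gives 2300 nM in this assay, a step of a 2.0-fold lower number from compound 1 to compound 2 (0.31 log units; beyond the scatter). Compound 3 `CCCNC1=NS(=O)(=O)c2cc(F)c(Cl)cc2N1` keeps the propylamino group but differs from compound 1 in the core by fluoro in place of chloro on an aromatic carbon; in this assay compound 3 gives 45300 nM, a step of a 9.6-fold higher number from compound 1 to compound 3 (0.98 log units; beyond the scatter), which leaves compound 3 with the highest number of the three measured.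

Compound 4 `CC(C)NC1=NS(=O)(=O)c2cc(F)c(Cl)cc2N1` is not yet measured. It differs from compound 3 by isopropyl in place of propyl on an amine nitrogen, the same change as that between compound 1 and compound 2, made on the other core. Among the measured compounds shown here, only one measured instance of this change exists, so its transfer to the fluoro-bearing core is an assumption.

For compound 4 in this assay the expected value is 22000 nM, within an expected range of 9000 nM to 50000 nM. The step expected is a 2.1-fold lower number from compound 3 to compound 4 (0.31 log units; beyond the scatter). This expectation rests on the measured step of a 2.0-fold lower number from compound 1 to compound 2 (0.31 log units; beyond the scatter) on the core of compound 1.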

Compound 4, half-maximal effective concentration: 41500 nM
Compound 4: the middle estimate sits 1.9-fold (0.28 log units) below what was measured; low and high end bracket the measured number.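

In this assay the change of isopropyl in place of propyl gives a 1.1-fold lower number from compound 3 to compound 4 (0.04 log units; within the scatter) on the fluoro-bearing core, and this step does not separate from the one on the dichloro core: the same change on two cores in this assay, a 2.0-fold lower number (0.31 log units; beyond the scatter) from compound 1 to compound 2 and a 1.1-fold lower number (0.04 log units; within the scatter) from compound 3 to compound 4, 1.9-fold (0.27 log units) apart, within the scatter of two such steps. The change of fluoro in place of chloro, read on the isopropylamino pair, gives an 18-fold higher number from compound 2 to compound 4 (1.26 log units; beyond the scatter), and it too carries over from the propylamino pair without a resolved difference: the same change on two cores in this assay, a 9.6-fold higher number (0.98 log units; beyond the scatter) from compound 1 to compound 3 and an 18-fold higher number (1.26 log units; beyond the scatter) from compound 2 to compound 4, 1.9-fold (0.27 log units) apart, within the scatter of two such steps. Among the compounds shown here, with only two pairs for each change, the steps are compatible with transfer between these two cores, but this does not show that the steps are equal or that either would hold on any further core.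

From the compounds shown here alone, it remains open whether a longer chain such as butyl, or a ring such as cyclopropyl, on the amine nitrogen would shift the number in this assay on either core. Also open, going by these compounds, is how bromo or trifluoromethyl in place of the fluoro would compare, and whether the step from propylamino to isopropylamino would carry over to such cores.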